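The source may hold more compounds than are shown below. What is called first, only, known or untested is meant among the compounds shown, and "the series" means these compounds.

Measured compounds:
compound 1 `O=C1CCC(CCN2CC(N3CCOCC3=O)C2)(c2ccc(Cl)c(Cl)c2)CN1Cc1ccccc1` — 2.51 nM in an assay on isolated protein (artery, Oryctolagus cuniculus) with Substance-P receptor (Homo sapiens) as the target; on this read-out higher numbers stand for weaker binding and lower numbers for tighter binding
compound 2 `CS(=O)(=O)N1CCN(C2CN(CCC3(c4ccc(Cl)c(Cl)c4)CCC(=O)N(Cc4ccccc4)C3)C2)CC1` — 0.631 nM in this assay

Of the two numbers, compound 2 gives the lower one; the only step shown, a 4.0-fold lower number from compound 1 to compound 2 (0.60 log units; beyond the scatter), is a modest one that places compound 2 ahead of compound 1. Compound 3 `O=C1CCC(CCN2CC(N3CCC(O)C3)C2)(c2ccc(Cl)c(Cl)c2)CN1Cc1ccccc1` has not been measured. Compared with compound 2 the change is 3-hydroxypyrrolidin-1-yl in place of 4-(methylsulfonyl)piperazin-1-yl on a saturated ring carbon. No measured step touches this exact exchange; the single step shown concerns a different group at the same place, so it offers only the rough size of a change on this ring carbon. Both compound 1 and compound 3 lack the sulfonyl-bearing six-membered ring of compound 2, so the expectation for compound 3 is a step back toward the number of compound 1, a 2.5-fold higher number from compound 2 to compound 3 (0.40 log units; beyond the scatter). Compound 3 is therefore estimated at 1.6 nM, with a range from 0.5 nM to 5 nM.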

Compound 3, dissociation constant: 2 nM
Estimate against measurement, compound 3: 1.3-fold (0.10 log units) below; the range from low to high includes it.
By their numbers in this assay, from the lowest: compound 2; then compounds 3 and 1 (each within the scatter of the next).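

In this assay, 3-hydroxypyrrolidin-1-yl in place of 4-(methylsulfonyl)piperazin-1-yl on this saturated ring carbon gives a measured step at this exact exchange (a 3.2-fold higher number from compound 2 to compound 3 (0.50 log units; beyond the scatter)). 3-Hydroxypyrrolidin-1-yl and 3-oxomorpholin-4-yl, two different groups at the same place, stay within the scatter of each other (a 1.3-fold lower number from compound 1 to compound 3 (0.10 log units; within the scatter)), so among these three compounds only 4-(methylsulfonyl)piperazin-1-yl stands apart. Nothing given here accounts for either step.

The compounds shown do not separate the methylsulfonyl group from the piperazine ring that carries it, a question that an unsubstituted piperazin-1-yl or a 4-acetylpiperazin-1-yl at this place would address. Also open, going by these compounds, is whether the hydroxyl of 3-hydroxypyrrolidin-1-yl matters, which plain pyrrolidin-1-yl would test against compound 3.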